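The source may hold more compounds than are shown below. What is called first, only, known or untested is meant among the compounds shown, and "the series" means these compounds.

Measured so far in an ADME assay for permeability, using PAMPA, at pH 7.4 (on this read-out higher numbers stand for higher permeability and lower numbers for lower permeability), are three compounds:
- compound 1 `CSc1ccc(NC(=O)Nc2cc(C)nc3ccccc23)cc1` gives 473 10^-6 cm/s
- compound 2 `CC(=O)c1ccc(NC(=O)Nc2cc(C)nc3ccccc23)cc1` gives 473 10^-6 cm/s
- compound 3 `Cc1cc(NC(=O)Nc2ccc(F)c(F)c2)c2ccccc2n1` gives 478 10^-6 cm/s

In this assay compound 3 stands level with compound 1 and compound 2, within the scatter of both. The three values give no ordering among these compounds.

The next compound to be measured is compound 4 `Cc1cc(NC(=O)Nc2ccc(F)cc2)c2ccccc2n1` and the change from compound 3 is hydrogen in place of fluoro on an aromatic carbon in one place. This is hydrogen in place of fluoro on an aromatic carbon, ortho to a fluoro group and meta to a large group.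

Going by the values given here, no measured step covers this exchange directly. Among the compounds with values here, the only step in hand is no change at the digits printed from compound 1 to compound 2 (within the scatter) and it concerns a different exchange, acetyl in place of methylsulfanyl on an aromatic carbon. It therefore bears on the question only indirectly. With that step flat and compound 3 at 478 10^-6 cm/s in line with the other two values, the data offer no reason to expect a shift in either direction.

The expected step is a 1.0-fold lower number from compound 3 to compound 4 (0.01 log units; within the scatter) and it is estimated to stay within the scatter. Compound 4 is estimated at 470 10^-6 cm/s with an expected range of 300 10^-6 cm/s to 700 10^-6 cm/s on this read-out.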

Compound 4, apparent permeability: 801 10^-6 cm/s
The estimate for compound 4 lay 1.7-fold (0.23 log units) below the measured number; measured number above the stated range.
By their numbers in this assay, from the lowest: compounds 1, 2, 3 and 4 (each within the scatter of the next).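

Going by these compounds alone, at the aromatic carbon ortho to a fluoro group and meta to a large group, hydrogen in place of fluoro gives a 1.7-fold higher number from compound 3 to compound 4 (0.22 log units; within the scatter) in this assay, the first direct reading for this exchange, and it shows that losing this one fluoro does not take the number beyond the scatter. The other two new comparisons read the same way: fluoro in place of acetyl gives a 1.7-fold higher number from compound 2 to compound 4 (0.23 log units; within the scatter) and fluoro in place of methylsulfanyl gives a 1.7-fold higher number from compound 1 to compound 4 (0.23 log units; within the scatter), so the four compounds still form no ordering in this assay. No independent measurement accompanies these values, and nothing can be said about what lies behind them.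

The compounds shown set only hydrogen and fluoro against each other at this carbon, so it remains open whether an amine, a carboxylic acid or a methoxy group there would move the number beyond the scatter. Also open, going by these compounds, is whether the remaining fluoro of compound 4 could give way to hydrogen or to chlorine with an equally flat result.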